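From 4-Methylphenyl to 2-Chlorophenyl on a Carbonyl Carbon

The source may hold more compounds than are shown below. What is called first, only, known or untested is meant among the compounds shown, and "the series" means these compounds.

In a functional assay on A549 cells (Homo sapiens) for antiproliferative activity, read by MTT assay, with a stated time of 24 h (a higher number here means a weaker inhibitor, a lower number a stronger inhibitor), compound 1 (`O=C(NNc1ccccc1F)c1ccccc1NS(=O)(=O)c1cnc(O)nc1O`) gives 9610 nM as its half-maximal inhibitory concentration, and compound 2 (`Cc1ccccc1C(=O)NNC(=O)c1ccccc1NS(=O)(=O)c1cnc(O)nc1O`) gives 5450 nM on the same read-out. Compound 3 (`Cc1ccc(C(=O)NNC(=O)c2ccccc2NS(=O)(=O)c2cnc(O)nc2O)cc1`) has only a limit, > 20000 nM and not a number (the limit of > 20000 nM in this assay, at which 1 of the 3 values shown sits).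

Compound 4 (`O=C(NNC(=O)c1ccccc1NS(=O)(=O)c1cnc(O)nc1O)c1ccccc1Cl`) differs from compound 3 by one group, with 2-chlorophenyl in place of 4-methylphenyl on a carbonyl carbon. For the measured compounds named here, no measured step makes this exact change. The nearest is an at least 3.6-fold higher number from compound 2 to compound 3 (0.56 log units; beyond the scatter) with 4-methylphenyl in place of 2-methylphenyl at that same place. A second step, an at least 2.0-fold higher number from compound 1 to compound 3 (0.31 log units; beyond the scatter) also ends at compound 3, while a 1.8-fold lower number from compound 1 to compound 2 (0.25 log units; within the scatter) stays small.

Compound 4 carries 2-chlorophenyl where compound 2, at 5450 nM in this assay, carries 2-methylphenyl, so a value near that of compound 2 is expected. This means an expected at least 2.8-fold lower number from compound 3 to compound 4 (0.45 log units; beyond the scatter) in this assay as a step towards a stronger inhibitor. The estimate for compound 4 is 7000 nM (expected range 2500 nM to 20000 nM).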

Compound 4, half-maximal inhibitory concentration: 5290 nM
For compound 4 the middle estimate is 1.3-fold (0.12 log units) above the measured one; the measured number falls inside the stated range.
By their numbers in this assay, from the lowest: compounds 4, 2 and 1 (each within the scatter of the next). At a limit, above all of these: compound 3.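

Chloro in place of methyl on an aromatic carbon gives a 1.0-fold lower number from compound 2 to compound 4 (0.01 log units; within the scatter) in this assay, so the two groups cannot be told apart in this assay. Replacing 4-methylphenyl with 2-chlorophenyl on the carbonyl carbon gives an at least 3.7-fold lower number from compound 3 to compound 4 (0.57 log units; beyond the scatter), so the gap first seen with 2-methylphenyl is not tied to a methyl group, while the swap for 2-fluorophenyl on an amine nitrogen gives only a 1.8-fold lower number from compound 1 to compound 4 (0.26 log units; within the scatter). Compound 3 has only a limit, so its steps are bounds and not exact sizes: the limit of > 20000 nM in this assay, at which 1 of the 4 values shown sits.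

The compounds shown leave open whether the gap follows the place on the ring or the group itself, which 4-chlorophenyl on the same carbonyl carbon would separate. They also leave open whether an amine or a methoxy group in place of the chloro would stay in this range.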